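The compounds below may be only part of what the source reports. "The series", "measured", "known", "first", "only" and "open" are said of these compounds alone.

Compound 1, `CCN(Cc1cccc(F)c1)C(=O)C1CCN(S(=O)(=O)c2ccc3cn[nH]c3c2)CC1`, reaches 89% in a functional assay on CHO cells for positive allosteric modulation of muscarinic acetylcholine receptor M5 (Homo sapiens), read by calcium flux; a higher number here means a larger maximal response, a lower number a smaller maximal response. Compound 2, `CCN(Cc1cccc(OC)c1)C(=O)C1CCN(S(=O)(=O)c2ccc3cn[nH]c3c2)CC1`, reaches 85% in this assay. For the measured compounds named here, compound 2 therefore holds the lower of the two numbers measured so far, yet its nearest neighbour is compound 1, and the step of a number 4 percentage points lower from compound 1 to compound 2 (within the scatter) stays within the usual scatter, so the two compounds cannot be told apart on these data.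

Compound 3, `CCN(Cc1ccccc1OC)C(=O)C1CCN(S(=O)(=O)c2ccc3cn[nH]c3c2)CC1`, is the next compound to be tested. It has the same atoms as compound 2, joined differently: 2-methoxyphenyl in place of 3-methoxyphenyl on a saturated chain carbon bound to an amide-type nitrogen.

Going by the values given here, only one measured step exists, a number 4 percentage points lower from compound 1 to compound 2 (within the scatter), and it concerns a different kind of change, methoxy in place of fluoro on an aromatic carbon, not the same methoxyphenyl group rebuilt as 2-methoxyphenyl. Among the compounds with values here, no measured pair shows how this assay answers such a rearrangement. Within the data shown here, the single known step being within the scatter gives no reason to expect a large move, so the estimate for compound 3 is 82%, between 55% and 100%, which means an expected step of a number 3 percentage points lower from compound 2 to compound 3 (within the scatter), with the wide range reflecting that nothing measured bears directly on this change.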

Compound 3, largest response reached (reported as percent of maximum), in percent of the reference or control that the assay uses: 92%
Compound 3: the middle estimate sits 10 percentage points below what was measured; measured number inside the range.
By their numbers in this assay, from the lowest: compounds 2, 1 and 3 (each within the scatter of the next).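

In this assay, for the compounds shown here, rebuilding the group on a saturated chain carbon bound to an amide-type nitrogen from 3-methoxyphenyl to 2-methoxyphenyl gives a number 7 percentage points higher from compound 2 to compound 3 (within the scatter) and is the first measured case of the same atoms being joined differently at this place. Putting 2-methoxyphenyl in place of 3-fluorophenyl at the same place gives a number 3 percentage points higher from compound 1 to compound 3 (within the scatter) and so changes both the substituent and where it is attached, yet this step also cannot be told from repeat-to-repeat variation. Across these three phenyl groups, then, this place shows no change in the largest response that rises above the scatter, and nothing at hand explains why the numbers stay so close.

As far as these compounds go, the three compounds share the same core and differ only in a small group on the phenyl ring, so it remains open whether this place would still give a similar response with an amine or a carboxylic acid on that ring, or with a longer chain in place of the benzyl group. These numbers describe only the largest response reached, which leaves open how much of each compound is needed to reach it.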